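A few compounds are considered here, and "the series" means these few. Any claim that something is new, unique, unknown or untested is made for them only; others in the source may bear on it.

Measured so far in an ADME assay on SW480 cells (Homo sapiens) for cytotoxicity, read by MTT assay, with a stated time of 72 h; on this read-out lower numbers stand for stronger inhibition and higher numbers for weaker inhibition:
compound 1, `Cc1ccc(NC(=O)c2cccc(/C=C3\CC(=O)N(c4ccccc4)C3=O)c2)cc1`: > 100000 nM, which is a limit of the assay the limit of > 100000 nM in this assay, at which 1 of the 3 values shown sits.
compound 2, `Cc1ccc(N2C(=O)C/C(=C\c3cccc(C(=O)Nc4cccc(F)c4)c3)C2=O)cc1`: 96900 nM
compound 3, `CCc1cccc(NC(=O)c2cccc(/C=C3\CC(=O)N(c4ccccc4)C3=O)c2)c1`: 88600 nM

Compound 3 stands level with compound 2, the two numbers lying within the scatter of each other, while compound 1 reports only a limit. Going by the values given here, the single one-point step seen so far, an at least 1.1-fold lower number from compound 1 to compound 3 (0.05 log units; that floor lies within the scatter), also stays within the scatter. Compound 4, `O=C(Nc1cccc(F)c1)c1cccc(/C=C2\CC(=O)N(c3ccccc3)C2=O)c1`, is not yet measured; it differs from compound 3 by fluoro in place of ethyl on an aromatic carbon. Among the compounds with values here, no measured step carries this exchange, and the one measured step is flat, so no movement beyond the scatter is expected in this assay from compound 3 to compound 4, estimated as a 1.1-fold higher number from compound 3 to compound 4 (0.03 log units; within the scatter). For compound 4 the expected value is 95000 nM, between 50000 nM and 180000 nM.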

Compound 4, half-maximal inhibitory concentration: > 100000 nM
Compound 4 ended at the assay's limit; the forecaster's own chance of this, stated with the estimate: 40%; at least 1.0-fold (0.02 log units) between middle value and limit.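

In this assay, fluoro in place of ethyl gives an at least 1.1-fold higher number from compound 3 to compound 4 (0.05 log units; that floor lies within the scatter), and hydrogen in place of methyl gives an at least 1.0-fold higher number from compound 2 to compound 4 (0.01 log units; that floor lies within the scatter). Neither floor leaves the scatter, so neither exchange is shown to move the number, and the step between the two limit compounds cannot be read. Compound 4 reports only a limit of the assay, the second in the set: the limit of > 100000 nM in this assay, at which 2 of the 4 values shown sit.

Any true size of these steps stays hidden behind that limit. As far as these compounds go, whether an amine or a carboxylic acid at this position would give a number clear of the limit remains open.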